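A few compounds are considered here, and "the series" means these few. Any claim that something is new, unique, unknown or untested is made for them only; others in the source may bear on it.

Compound 1 `CC(C(=O)NCc1ccc(C(F)(F)F)nc1Cl)c1ccc(NS(C)(=O)=O)c(F)c1` gives 0.2 nM in an assay on CHO cells for antagonist activity at transient receptor potential cation channel subfamily V member 1 (Homo sapiens), read by FLIPR and calcium flux; on this read-out lower numbers stand for stronger inhibition and higher numbers for weaker inhibition. Compound 2 `CC(C(=O)NCc1ccc(C(F)(F)F)nc1C1=CCC(C)(C)CC1)c1ccc(NS(C)(=O)=O)c(F)c1` gives 0.2 nM in this assay.

Within the data shown here, compound 2 stands level with compound 1 on these numbers: the one measured step, no change at the digits printed from compound 1 to compound 2 (within the scatter), lies within the scatter. Compound 3 `CC(C)=Cc1nc(C(F)(F)F)ccc1CNC(=O)C(C)c1ccc(NS(C)(=O)=O)c(F)c1` is not yet measured in this assay; it differs from compound 2 in one place, (2-methylprop-1-en-1-yl in place of 4,4-dimethylcyclohex-1-en-1-yl on an aromatic carbon). Among the measured compounds shown here, the only step that bears on this position is no change at the digits printed from compound 1 to compound 2 (within the scatter), which shows that a chloro and a 4,4-dimethylcyclohex-1-en-1-yl group at this carbon give the same reading. Since two quite different groups there left the value unchanged, a third group at the same carbon is expected to leave it unchanged as well, so the step of a 1.5-fold higher number from compound 2 to compound 3 (0.18 log units; within the scatter) is expected to stay within the scatter. Compound 3 is therefore estimated at 0.3 nM in this assay, with a range from 0.1 nM to 1.5 nM.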

Compound 3, inhibition constant: 11.5 nM
Compound 3: middle estimate off by 38-fold (1.58 log units), on the low side, outside the stated range (above it).
By their numbers in this assay, from the lowest: compounds 1 and 2 (each within the scatter of the next); then compound 3.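

In this assay, swapping the 4,4-dimethylcyclohex-1-en-1-yl group for 2-methylprop-1-en-1-yl gives a 58-fold higher number from compound 2 to compound 3 (1.76 log units; beyond the scatter), and swapping chloro for the same group gives a 58-fold higher number from compound 1 to compound 3 (1.76 log units; beyond the scatter). This carbon on the ring is therefore not indifferent to what it carries: the match between chloro and the 4,4-dimethylcyclohex-1-en-1-yl group does not extend to every group, and among these three the heavy-atom count does not order the readings, since the group with the intermediate count stands apart. Nothing given here explains this difference.

The compounds shown do not separate the loss of the ring from the open chain itself. A cyclohexyl ring, an isobutyl chain or a phenyl ring at this carbon would each bear on that question.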